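A few compounds are considered here, and "the series" means these few. Any claim that something is new, unique, unknown or untested is made for them only; others in the source may bear on it.

Measured so far:
compound 1 `N#Cc1ccc(Nc2nc(Oc3ccnc4ccccc34)nc(N3CCN(c4ncccn4)CC3)n2)cc1C(F)(F)F` — > 100000 nM in a functional assay on DU-145 cells (Homo sapiens) for cytotoxicity, read by sulforhodamine B assay, with a stated time of 48 h (on this read-out higher numbers stand for lower toxicity in this test and lower numbers for higher toxicity in this test), a limit of the assay
compound 2 `CN1CCN(c2nc(Nc3ccc(C#N)c(C(F)(F)F)c3)nc(Oc3ccnc4ccccc34)n2)CC1` — > 100000 nM in this assay, a limit of the assay

In this assay compound 1 gives > 100000 nM, which is a limit and not a number. In this assay compound 2 gives > 100000 nM, likewise a limit. The step that the two limits leave unreadable from compound 1 to compound 2 therefore cannot be read from the two values. Within the data shown here, compound 2 stands at the limit of the assay, as does the only other value shown (the limit of > 100000 nM in this assay, at which 2 of the 2 values shown sit); nothing so far places any compound at a readable number.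

Compound 3 `N#Cc1ccc(Nc2nc(Oc3ccnc4ccccc34)nc(N3CCN(c4ccc(F)cc4)CC3)n2)cc1C(F)(F)F` is not yet measured. It differs from compound 2 by 4-fluorophenyl in place of methyl on an amine nitrogen in a ring. Among the measured compounds shown here, the single measured step, from compound 1 to compound 2, changes a group on the same ring nitrogen but is itself unreadable, so no measured step gives a size for an aryl group replacing methyl here. With both measured compounds at the limit, the expected step of a number no higher from compound 2 to compound 3 (the limit leaves the size open) is none that can be read beyond the scatter, and compound 3 is expected to sit at the limit as well. For compound 3 in this assay the estimate is 100000 nM, with a range from 30000 nM to 300000 nM.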

Compound 3, concentration lethal to 50% of the cells: > 100000 nM
Compound 3: no number, only a limit (the forecaster's own chance of this, stated with the estimate: 70%); the middle value sits exactly at the limit.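

No step among compound 1, compound 2 and compound 3 can be read in this assay; all three values are limits of the assay and not numbers: the limit of > 100000 nM in this assay, at which 3 of the 3 values shown sit.

The compounds shown leave open what number any of the three would give, and so whether the group on the amine nitrogen in the ring matters for this read-out at all.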